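Amide nitrogen series: from isopropyl to 1-phenylethyl

This account rests on a few compounds, and the source may have more. Where it says the series, first, only, none or still open, it means among the compounds named here.

Values measured in a functional assay on U-937 cells (Homo sapiens) for antiproliferative activity, read by MTT assay, with a stated time of 24 h (a higher number here means a weaker inhibitor, a lower number a stronger inhibitor), so far:
- compound 1 `CCCCc1oc2ccccc2c1C(=O)c1ccc(OCC(N)=O)cc1` gives 42200 nM
- compound 2 `CCCCc1oc2ccccc2c1C(=O)c1ccc(OCC(=O)NC(C)C)cc1` gives 17500 nM

Compound 2 has the lower of the two numbers and is the reference point for the next comparison. The next compound, compound 3 `CCCCc1oc2ccccc2c1C(=O)c1ccc(OCC(=O)N[C@@H](C)c2ccccc2)cc1`, carries 1-phenylethyl in place of isopropyl on an amide-type nitrogen. The entering group brings one six-membered aromatic ring of carbon only and one defined stereocentre.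

Among the compounds with values here, only one measured step bears on this change. Isopropyl in place of hydrogen on an amide-type nitrogen gave a 2.4-fold lower number from compound 1 to compound 2 (0.38 log units; beyond the scatter), a modest step beyond the scatter. Within the data shown here, a single step does not establish a trend, and no measured compound has a ring on this nitrogen, so the size of the next step is poorly constrained. A further modest fall in this assay is nevertheless expected, in the same direction as that one step. The estimate amounts to a 2.2-fold lower number from compound 2 to compound 3 (0.34 log units; beyond the scatter) as the expected step. Compound 3 is expected at 8000 nM within an estimated range of 2500 nM to 22000 nM on present evidence.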

Compound 3, half-maximal inhibitory concentration: 33800 nM
Compound 3: the middle estimate sits 4.2-fold (0.63 log units) below what was measured, and the stated range ends below it.
By their numbers in this assay, from the lowest: compounds 2, 3 and 1 (each within the scatter of the next, the first and the last beyond it).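

Notes on the amide nitrogen: in this assay, the exchange of isopropyl for 1-phenylethyl gives (a 1.9-fold higher number from compound 2 to compound 3 (0.29 log units; within the scatter)), and 1-phenylethyl in place of hydrogen gives (a 1.2-fold lower number from compound 1 to compound 3 (0.10 log units; within the scatter)). Within the data shown here, the only step beyond the scatter among the three compounds therefore remains the one for isopropyl in place of hydrogen (a 2.4-fold lower number from compound 1 to compound 2 (0.38 log units; beyond the scatter)), while compound 3 cannot be separated from either compound 1 or compound 2, so the position accepts a group with a six-membered aromatic ring and a defined stereocentre without a readable change from either neighbour, and a larger group on this nitrogen does not extend the step seen with isopropyl. No measurement shown here accounts for this result.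

Open, as far as these compounds go, is whether the stereocentre matters, which would take the mirror-image 1-phenylethyl group to show, and whether the methyl on that carbon matters, which a benzyl group would test. Also open, from the compounds shown here alone, is how this nitrogen responds to a saturated ring such as cyclohexyl, to a longer chain such as n-butyl, or to a chain ending in an amine or a carboxylic acid.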